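Taking Away a Methoxy Group: What to Expect

A few compounds are considered here, and "the series" means these few. Any claim that something is new, unique, unknown or untested is made for them only; others in the source may bear on it.

Measured so far in a functional assay on the whole organism (strain albino) for inhibition, with Rattus norvegicus as the target, read by paw edema, with a stated time of 1 h, at a dose of 0.28 mmol/kg by the oral route; a lower number here means less inhibition, a higher number more inhibition at the dose given (going by the name of the read-out):
compound 1 `CCn1c(SCC(=O)c2ccccc2)nnc1-c1cc(OC)c(OC)c(OC)c1` gives 29%.
compound 2 `CCn1c(SCC(=O)c2ccccc2)nnc1-c1ccc(OC)c(OC)c1` gives 42%.
compound 3 `CCn1c(SC/C(=N/O)c2ccccc2)nnc1-c1ccc(OC)cc1` gives 69%.

Compound 2 differs from compound 1 by hydrogen in place of methoxy on an aromatic carbon, and in this assay this gave a number 13 percentage points higher from compound 1 to compound 2 (beyond the scatter). Compound 4 `CCn1c(SC/C(=N/O)c2ccccc2)nnc1-c1ccccc1`, not yet measured, differs from compound 3 by hydrogen in place of methoxy on an aromatic carbon, the same kind of change, but here the group that leaves sits para to a large group, whereas in compound 1 it sits ortho to a methoxy group, meta to a large group and meta to a methoxy group. The difference between the core of compound 1 and the core of compound 3 is not broken down here. Compound 3 already stands highest of the three measured numbers. Because a number 13 percentage points higher from compound 1 to compound 2 (beyond the scatter) was modest and the surroundings of the change differ, only a small step is expected from compound 3 to compound 4, a number 3 percentage points higher from compound 3 to compound 4 (within the scatter). Compound 4 is therefore estimated at 72%, most likely between 54% and 86%.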

Compound 4, a percentage reported as inhibition, in the whole organism at one dose (the size of the read-out at that dose, not a potency): 65%
The estimate for compound 4 lay 7 percentage points above the measured number; the range from low to high includes it.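

In this assay, among these compounds, replacing methoxy with hydrogen gave a number 4 percentage points lower from compound 3 to compound 4 (within the scatter), so on this core the change from 4-methoxyphenyl to phenyl produced no step that can be told from the scatter. Among the compounds shown here, the same change did not carry over with the same result from one core to the other: the same change on two cores in this assay, a number 13 percentage points higher (beyond the scatter) from compound 1 to compound 2 and a number 4 percentage points lower (within the scatter) from compound 3 to compound 4, 17 percentage points apart, beyond the scatter of two such steps With only two pairs, this does not show whether the core or the different surroundings of the methoxy group that leaves account for that gap.

The compounds shown leave open what an amine or a carboxylic acid would do in place of the hydrogen on the phenyl ring of compound 4. On these data alone, how the change would behave on a third core also remains open.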